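This account rests on a few compounds, and the source may have more. Where it says the series, first, only, none or still open, it means among the compounds named here.

Measured compounds in an ADME assay on HFF cells (Homo sapiens) for cytotoxicity, read by MTT assay, with a stated time of 72 h; on this read-out lower numbers stand for stronger inhibition and higher numbers for weaker inhibition:
compound 1, `COc1ccc(-c2cn(C/C=C3\OC(=O)C(OCc4ccccc4)=C3OCc3ccccc3)nn2)cc1`: > 100000 nM
compound 2, `Cc1ccc(S(=O)(=O)NCc2cn(C[C@H](O)[C@H]3OC(=O)C(OCc4ccccc4)=C3OCc3ccccc3)nn2)cc1`: 50 nM
compound 3, `O=C1O[C@H]([C@@H](O)Cn2cc(-c3cc(F)cc(F)c3)nn2)C(OCc2ccccc2)=C1OCc1ccccc1`: > 100000 nM

Compound 1 gives > 100000 nM, which is a limit of this assay and not a number. Compound 3 also gives > 100000 nM, again a limit. Compound 2 stands apart with 50 nM. For the measured compounds named here, the only step between measured compounds that differ in one place is an at least 2000-fold higher number from compound 2 to compound 3 (3.30 log units; beyond the scatter), a change on the aromatic carbon of the ring attached to the triazole. Compound 1 therefore sits at the limit of > 100000 nM in this assay, at which 2 of the 3 values shown sit, and with a limit there is no number from which a step can be measured.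

The unmeasured compound 4, `Cc1ccc(-c2cn(C/C=C3\OC(=O)C(OCc4ccccc4)=C3OCc3ccccc3)nn2)cc1`, differs from compound 1 by methyl in place of methoxy on an aromatic carbon. Going by the values given here, no measured step involves this exchange, so none bears directly on it; the one large step concerns a different group and gives no guide to the size of a methyl-for-methoxy swap. With compound 1 at a limit, compound 4 is expected to show no step beyond the scatter, so the estimated step is a number no higher from compound 1 to compound 4 (the limit leaves the size open). Compound 4 is thus estimated at 100000 nM, within a range from 30000 nM to 300000 nM, most likely reported again as a limit.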

Compound 4, half-maximal inhibitory concentration: > 100000 nM
Compound 4 ended at the assay's limit; the forecaster's own chance of this, stated with the estimate: 75%; the middle value sits exactly at the limit.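

In this assay compound 4 gives > 100000 nM, which is a limit of the assay and not a number. Compound 1 also sits at a limit, so no step can be read between compound 1 and compound 4: the limit of > 100000 nM in this assay, at which 3 of the 4 values shown sit.

The compounds shown leave open what methyl in place of methoxy does to the number in this assay.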